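Methyl in Place of Chloro in a Weak Series

A few compounds are considered here, and "the series" means these few. Any claim that something is new, unique, unknown or untested is made for them only; others in the source may bear on it.

Compound 1, `O=S(=O)(Nc1ccc2oc(-c3ccccc3)nc2c1)c1cccc(Cl)c1`, gives in an assay on isolated protein for inhibition of malate dehydrogenase, mitochondrial (Sus scrofa), with stated times of 45 min and 30 min (a lower number here means a stronger inhibitor, a higher number a weaker inhibitor), only a limit: > 63000 nM.
Compound 2, `O=S(=O)(Nc1ccc(-c2nc3ccccc3o2)cc1)c1cccc(C(F)(F)F)c1`, gives in this assay only a limit: > 63000 nM.
Compound 3, `O=S(=O)(Nc1ccc(-c2nc3ccccc3o2)cc1)c1ccc(C(F)(F)F)cc1`, gives in this assay only a limit: > 63000 nM.

Going by the values given here, compound 1 cannot be placed above or below its two companions, because of the limit of > 63000 nM in this assay, at which 3 of the 3 values shown sit; none of the three shows a measured number, so no step between measured compounds can be drawn, and no pattern can be read from them. The unmeasured compound 4, `Cc1cccc(S(=O)(=O)Nc2ccc3oc(-c4ccccc4)nc3c2)c1`, differs from compound 1 in one place only: methyl in place of chloro on an aromatic carbon. Since every value in hand is a limit, the expectation for compound 4 is that it will also fall short of a measurable number, and the step that the limit leaves unreadable from compound 1 to compound 4 is expected to stay within the scatter, in no direction. For compound 4 the estimate is therefore 100000 nM, with a range from 30000 nM to 400000 nM, and most likely the assay will again report only a limit.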

Compound 4, half-maximal inhibitory concentration: > 63000 nM
Compound 4: only a limit was reported; the forecaster's own chance of this, stated with the estimate: 85%; the middle value is on the limit's open side.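

No step can be read from compound 1 to compound 4, because both results are limits and not numbers: the limit of > 63000 nM in this assay, at which 4 of the 4 values shown sit. The compounds shown leave open how methyl and chloro compare at this place, and what structure would give a measurable number in this assay.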